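The source may hold more compounds than are shown below. What is called first, only, known or untested is meant among the compounds shown, and "the series" means these compounds.

Among the measured compounds shown here, compound 2 `COc1ccc([C@@H]2C/C(=N\O)c3c(O)cc(OCc4cn(Cc5ccccc5C)nn4)cc3O2)cc1O` is one of two compounds so far measured in a functional assay on RAW264.7 cells (Mus musculus) for inhibition, read by Griess assay, with stated times of 2 h and 24 h; a higher number here means a weaker inhibitor, a lower number a stronger inhibitor. In this assay compound 2 gives 18000 nM. Its companion, compound 1 `C#CCOc1cc(O)c2c(c1)O[C@H](c1ccc(OC)c(O)c1)C/C2=N\O`, gives in this assay a value of 19100 nM; the two numbers lie within the usual scatter of each other, so neither can be called the stronger inhibitor on the present evidence. The step to the unmeasured compound 3 `CCCCn1cc(COc2cc(O)c3c(c2)O[C@H](c2ccc(OC)c(O)c2)C/C3=N\O)nn1` is a single change: propyl in place of 2-methylphenyl on a saturated chain carbon bound to an aromatic nitrogen. For the measured compounds named here, no measured pair shows this kind of change, so there is nothing to guide its size; the two values seen so far merely sit close together. The step from compound 2 to compound 3 is therefore expected to be small, no larger than the scatter, as a 1.2-fold higher number from compound 2 to compound 3 (0.09 log units; within the scatter). Compound 3 is estimated to give 22000 nM in this assay, with a likely range from 9000 nM to 50000 nM.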

Compound 3, half-maximal inhibitory concentration: 8900 nM
For compound 3 the middle estimate is 2.5-fold (0.39 log units) above the measured one; the measured number lies below the stated range.
By their numbers in this assay, from the lowest: compound 3; then compounds 2 and 1 (each within the scatter of the next).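

In this assay, the saturated chain carbon bound to an aromatic nitrogen proves responsive: propyl in place of 2-methylphenyl gives a 2.0-fold lower number from compound 2 to compound 3 (0.31 log units; beyond the scatter), a modest step, so the six-membered aromatic ring is not required there for the activity seen. Placing 1-butyl-1H-1,2,3-triazol-4-yl in place of ethynyl, on a saturated chain carbon bound to an oxygen on an aromatic ring, gives a 2.1-fold lower number from compound 1 to compound 3 (0.33 log units; beyond the scatter), a similarly modest step. Nothing available explains either step.

Going by these compounds, it remains open whether a shorter chain such as ethyl, a longer chain such as hexyl, or an amine or a carboxylic acid at the end of the butyl chain would shift the number further. A cyclohexylmethyl group could show whether the step follows the loss of the aromatic ring or the presence of the butyl chain.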